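A Trifluoromethyl Swap Among Well-Tolerated Compounds

The source may report more compounds than this note shows. Statements on the series, on what has been measured and on what is new or still open speak of the compounds shown alone.

So far, three compounds sharing one core have been tested in an ADME assay on HepG2 cells (Homo sapiens) for cytotoxicity, read by MTT assay, with a stated time of 72 h; a higher number here means that more compound is tolerated, a lower number that less compound is tolerated. Compound 1 (`O=[N+]([O-])c1c(CS(=O)(=O)c2ccccc2)nc2c(-c3ccc(Cl)cc3)cc(Cl)cn12`) gives > 3900 nM, which is a limit and not a number. Compound 2 (`O=[N+]([O-])c1c(CS(=O)(=O)c2ccccc2)nc2c(-c3ccc(O)cc3)cc(Cl)cn12`) gives > 12500 nM, which is also a limit. Compound 3 (`O=[N+]([O-])c1c(CS(=O)(=O)c2ccccc2)nc2c(-c3ccc(F)cc3F)cc(Cl)cn12`) gives > 7800 nM, again a limit, so it stands with the other two and has no exact value of its own.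

The next compound, compound 4 (`O=[N+]([O-])c1c(CS(=O)(=O)c2ccccc2)nc2c(-c3ccccc3C(F)(F)F)cc(Cl)cn12`), carries 2-(trifluoromethyl)phenyl in place of 2,4-difluorophenyl on an aromatic carbon. Two measured swaps of the aryl group at that carbon bear on this change: a step that the two limits leave unreadable from compound 1 to compound 3 and a step that the two limits leave unreadable from compound 2 to compound 3. Neither gives a size, so no step beyond the scatter is expected in this assay, in either direction. The expected change is a step that the limit leaves unreadable from compound 3 to compound 4. The estimate for compound 4 is 8000 nM, with an expected range from 3000 nM to 25000 nM, and the result may well be only a limit again.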

Compound 4, half-maximal cytotoxic concentration: 22700 nM
Compound 4: middle estimate off by 2.8-fold (0.45 log units), on the low side; low and high end bracket the measured number.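

In this assay, for the compounds shown here, compound 1, compound 2 and compound 3 each carry only a limit, so no step from any of them to compound 4 can be read. The compounds shown leave open whether changing the aryl group at this carbon shifts the tolerated concentration at all.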